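This account rests on a few compounds, and the source may have more. Where it says the series, first, only, none or still open, it means among the compounds named here.

Measured so far:
compound 1 `CCOC(=O)[C@@H](NC(=O)[C@H](NC(=O)CCCC(=O)O)[C@@H](O)CO)[C@@H](C)O[C@@H]1O[C@@H](C)[C@@H](O)C(O)C1O` gives 500000 nM
compound 2 `CCOC(=O)[C@@H](NC(=O)[C@@H]1C[C@H](O)CN1C(=O)CCCC(=O)O)[C@@H](C)O[C@@H]1O[C@@H](C)[C@@H](O)C(O)C1O` gives 1000000 nM

Both measured compounds are very weak in an assay on isolated protein for inhibition of E-selectin (Homo sapiens); on this read-out higher numbers stand for weaker inhibition and lower numbers for stronger inhibition. For the measured compounds named here, compound 2 stands highest of the two numbers; its only neighbour is compound 1, whose number in this assay is lower by an amount that is within the scatter, so the two are not separated by this read-out. Going by the values given here, no step between measured compounds is available to say what a change of the kind now considered does.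

Compound 3 `CCOC(=O)[C@@H](NC(=O)[C@@H]1C[C@@H](O)CN1C(=O)CCCC(=O)O)[C@@H](C)O[C@H]1O[C@@H](C)[C@@H](O)C(O)C1O` has not been measured. It differs from compound 2 in this way: the two compounds have the same atoms and bonds; at least one stereo element is drawn with a configuration in one of them and without one in the other: 2 of 9 stereo elements differ; a stereocentre at a saturated ring carbon is drawn S in compound 2 and R in compound 3; a stereocentre at a saturated ring carbon is drawn R in compound 2 and S in compound 3. Two stereocentres, each at a saturated ring carbon, are thus drawn inverted relative to compound 2. Among the compounds with values here, with no comparable step on record, no direction can be read from the data; the expectation is a step from compound 2 of no change at the digits printed from compound 2 to compound 3 (within the scatter), that is, none beyond the scatter, with wide uncertainty. Compound 3 is therefore expected to give about 1000000 nM in this assay, within a range of 300000 nM to 3000000 nM.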

Compound 3, half-maximal inhibitory concentration: 100000 nM
Beside the measured number, compound 3's estimate is 10-fold (1.00 log units) above it, and the stated range ends above it.
By their numbers in this assay, from the lowest: compound 3; then compounds 1 and 2 (each within the scatter of the next).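

In this assay, configuration alone moves the number: with atoms and bonds unchanged, inverting two stereocentres, each at a saturated ring carbon, gives a 10-fold lower number from compound 2 to compound 3 (1.00 log units; beyond the scatter). For the compounds shown here, compounds 1 and 2 were not separated by this read-out, so this is the first step that reads beyond the scatter, and it shows that the series responds to stereochemistry at these ring carbons. The step cannot be taken as a clean comparison of two fully defined stereoisomers, because of one feature of the drawings: the fact that one of compounds 2 and 3 is drawn with a defined configuration and the other without, at the place where they differ

From the compounds shown here alone, the two inversions occur together in compound 3, and the share of each ring carbon in the step remains open. Also open, going by these compounds, is how an amine in place of the ring hydroxyl would read in this configuration.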